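Cytotoxicity notes on the fused-core series, compounds 1 to 3

A few compounds are considered here, and "the series" means these few. Any claim that something is new, unique, unknown or untested is made for them only; others in the source may bear on it.

Measured so far:
compound 1, `Fc1ccc(-c2nc3c(NC4CC4)cccn3c2-c2ccnc(NC3CCCC3)n2)cc1`, 33000 nM
compound 2, `CCCCNc1cccn2c(-c3ccnc(NC4CCCC4)n3)c(-c3ccc(F)cc3)nc12`, 32000 nM

Both numbers come from an ADME assay on Vero cells (Chlorocebus sabaeus) for cytotoxicity; a higher number here means that more compound is tolerated, a lower number that less compound is tolerated. Compound 1 and compound 2 share the whole core and the cyclopentylamino group and differ only in the alkyl group on the ring nitrogen; the step of a 1.0-fold lower number from compound 1 to compound 2 (0.01 log units; within the scatter) shows the two values lying within the scatter of each other, so neither compound can be placed ahead of the other. Compound 2 therefore stands level with compound 1 on the numbers seen.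

Compound 3, `Fc1ccc(-c2nc3c(N4CCCC4)cccn3c2-c2ccnc(NC3CCCC3)n2)cc1`, is not yet measured. Its change from compound 2 is pyrrolidin-1-yl in place of butylamino on an aromatic carbon. Among the measured compounds shown here, only one measured step bears on this position: a 1.0-fold lower number from compound 1 to compound 2 (0.01 log units; within the scatter), which swapped one alkyl group for another on that nitrogen and moved the number by nothing beyond the scatter. That single step is a thin basis, and it does not cover closing the substituent into a ring, so the estimate for compound 3 in this assay is expected to stay close to compound 2, with a step of no change at the digits printed from compound 2 to compound 3 (within the scatter). The value expected for compound 3 is 32000 nM, within the range 15000 nM to 65000 nM.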

Compound 3, half-maximal cytotoxic concentration: > 40000 nM
Compound 3 gave a limit, no number; the forecaster's own chance of this, stated with the estimate: 10%; at least 1.2-fold (0.09 log units) between middle value and limit.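

In this assay compound 3 gives > 40000 nM, and this is a limit of the assay, not a number: the limit of > 40000 nM in this assay, at which 1 of the 3 values shown sits.

With pyrrolidin-1-yl in place of butylamino the reading is an at least 1.2-fold higher number from compound 2 to compound 3 (0.09 log units; that floor lies within the scatter), and with pyrrolidin-1-yl in place of cyclopropylamino it is an at least 1.2-fold higher number from compound 1 to compound 3 (0.08 log units; that floor lies within the scatter). Unlike the earlier pair, which only exchanged one alkyl group for another on a nitrogen that keeps its hydrogen-bond donor, these steps show that this aromatic carbon also carries a five-membered non-aromatic ring with no hydrogen-bond donor, and the limit gives no sign that less compound is tolerated.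

On these data alone, how far the true value of compound 3 lies from those of compound 1 and compound 2 stays open, as both floors lie within the scatter and the limit sets no upper bound. Also open, as far as these compounds go, is how this position responds to a six-membered ring such as morpholine or piperidine, to a carboxylic acid, or to a chain longer than butyl.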